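The source may report more compounds than this note shows. Statements on the series, on what has been measured and on what is new or still open speak of the compounds shown alone.

Compound 1 `O=c1cc(-c2ccccc2)oc2cc(OCCCN3CCN(c4ccccc4)CC3)ccc12` is measured in a functional assay for antagonist activity at Adrenergic receptor alpha-1 (Rattus norvegicus) (on this read-out higher numbers stand for weaker binding and lower numbers for tighter binding), at 6.65 nM. Compound 2 `Cc1ccc(N2CCN(CCCOc3ccc4c(=O)cc(-c5ccccc5)oc4c3)CC2)cc1` carries methyl in place of hydrogen on an aromatic carbon and in this assay compound 2 gives 20.7 nM; the step of a 3.1-fold higher number from compound 1 to compound 2 (0.49 log units; beyond the scatter). Compound 3 `O=c1cc(-c2ccc(Cl)cc2)oc2cc(OCCCCN3CCN(c4ccccc4)CC3)ccc12` has a different core, and the difference between the two cores is not broken down here; in this assay compound 3 gives 12.2 nM, which stands within the scatter of the values of compound 1 and compound 2. Compound 4 `Cc1ccc(N2CCN(CCCCOc3ccc4c(=O)cc(-c5ccc(Cl)cc5)oc4c3)CC2)cc1` is not yet measured. It differs from compound 3 by methyl in place of hydrogen on an aromatic carbon, the same change as that from compound 1 to compound 2. Because the earlier change gave a 3.1-fold higher number from compound 1 to compound 2 (0.49 log units; beyond the scatter), a step of about the same size is expected from compound 3 to compound 4, a 3.0-fold higher number from compound 3 to compound 4 (0.48 log units; beyond the scatter). Compound 4 is therefore estimated at 37 nM, with a range from 15 nM to 90 nM.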

Compound 4, dissociation constant: 3.18 nM
Estimate against measurement, compound 4: 12-fold (1.07 log units) above, outside the stated range (below it).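

In this assay, the change from phenyl to 4-methylphenyl gives a 3.8-fold lower number from compound 3 to compound 4 (0.58 log units; beyond the scatter), so neither the size nor the direction of the step carries over between these two cores: the same change on two cores in this assay, a 3.1-fold higher number (0.49 log units; beyond the scatter) from compound 1 to compound 2 and a 3.8-fold lower number (0.58 log units; beyond the scatter) from compound 3 to compound 4, 12-fold (1.08 log units) apart, beyond the scatter of two such steps

The two pairs show that the outcome of adding this methyl depends on the core. They do not show which feature of the cores is responsible, and they offer no rule for predicting the step on a further core.

From the compounds shown here alone, it remains open whether a core differing from that of compound 1 in only one place would give the higher or the lower number with this change. Going by these compounds, it also remains open how methoxy or fluorine would behave in place of the methyl on each core.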